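The source may hold more compounds than are shown below. What is called first, only, known or untested is meant among the compounds shown, and "the series" means these compounds.

Compound 1 `N#Cc1ccc(-c2nc(CO[C@@H]3COc4nc([N+](=O)[O-])cn4C3)cs2)cc1` was examined in an ADME assay on Vero cells (Chlorocebus sabaeus) for cytotoxicity, with a stated time of 72 h; on this read-out higher numbers stand for weaker inhibition and lower numbers for stronger inhibition. In this assay compound 1 gives only a limit, > 128000 nM. Compound 2 `O=[N+]([O-])c1cn2c(n1)OC[C@@H](OCc1csc(-c3ccc(F)cc3)n1)C2` differs from compound 1 by fluoro in place of cyano on an aromatic carbon, and the resulting step that the two limits leave unreadable from compound 1 to compound 2 cannot be sized. In this assay compound 2 likewise gives only a limit, > 128000 nM. Compound 3 `Cn1c(CO[C@@H]2COc3nc([N+](=O)[O-])cn3C2)cnc1-c1ccc(C#N)cc1` rests on a different core; how its core differs from that of compound 1 is not broken down here. In this assay compound 3 gives only a limit, > 128000 nM. All three measured values sit at the limit of > 128000 nM in this assay, at which 3 of the 3 values shown sit. Compound 4 `Cn1c(CO[C@@H]2COc3nc([N+](=O)[O-])cn3C2)cnc1-c1ccc(F)cc1` differs from compound 3 by fluoro in place of cyano on an aromatic carbon, the same change already seen between compound 1 and compound 2. Because compound 3 sits at the limit of > 128000 nM in this assay, at which 3 of the 3 values shown sit, and the earlier step that the two limits leave unreadable from compound 1 to compound 2 gave no readable shift, compound 4 is expected to move by a number no higher from compound 3 to compound 4 (the limit leaves the size open). Compound 4 is therefore estimated at 128000 nM, most probably reported again only as a limit.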

Compound 4, half-maximal inhibitory concentration: > 128000 nM
Compound 4 was reported as a limit; the forecaster's own chance of this, stated with the estimate: 85%; the middle value lies on the limit itself.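

In this assay, for the compounds shown here, compound 4 again gives only a limit (> 128000 nM), so no step from compound 3 to compound 4 can be read. The compounds shown leave open what any of them would actually measure, and whether fluoro in place of cyano changes it: the limit of > 128000 nM in this assay, at which 4 of the 4 values shown sit.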